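Biphenyl sulfonamides with hydroxymethyl anilines: cytotoxicity notes

The compounds below may be only part of what the source reports. "The series", "measured", "known", "first", "only" and "open" are said of these compounds alone.

The series shares a biphenyl sulfonamide linked to an aniline bearing hydroxymethyl. Compound 1 `O=S(=O)(Nc1cc(CO)cc(CO)c1)c1ccc(-c2ccc(Cl)cc2Cl)cc1` carries two hydroxymethyl groups and a dichlorophenyl; in a functional assay on J774 cells (Mus musculus) for cytotoxicity, read by resazurin assay, with a stated time of 72 h (a lower number here means a stronger inhibitor, a higher number a weaker inhibitor), compound 1 gives 2500 nM. Compound 2 `O=S(=O)(Nc1cccc(CO)c1)c1ccc(-c2ccc3cc[nH]c3c2)cc1` carries one hydroxymethyl and an indolyl group; in this assay compound 2 gives 2500 nM. Compound 2 therefore stands level with compound 1 at the digits shown, within the scatter, and no order between the two can be read. Compound 3 `O=S(=O)(Nc1ccc(-c2ccc(Cl)cc2Cl)cc1)c1cccc(CO)c1`, with the sulfonamide reversed, reaches only a limit of the assay and no number: compound 3 gives > 10000 nM. That limit is noted as the limit of > 10000 nM in this assay, at which 1 of the 3 values shown sits.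

Compound 4 `O=S(=O)(Nc1cccc(CO)c1)c1ccc(-c2ccc(F)cc2)cc1` is the next target. It differs from compound 2 by 4-fluorophenyl in place of 1H-indol-6-yl on an aromatic carbon. Within the data shown here, nothing among the measured pairs isolates this exchange, so no computed step exists for it. On the two values seen for the two-ring and one-ring aryl partners, the expectation for this assay is a step from compound 2 to compound 4 of a 1.6-fold higher number from compound 2 to compound 4 (0.20 log units; within the scatter), at the edge of the scatter and leaning weaker rather than stronger. Compound 4 is thus estimated at 4000 nM, with a range from 1500 nM to 12000 nM, and a real chance that only a limit is returned.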

Compound 4, half-maximal inhibitory concentration: 3500 nM
Beside the measured number, compound 4's estimate is 1.1-fold (0.06 log units) above it, within the range that was stated.
By their numbers in this assay, from the lowest: compounds 1, 2 and 4 (each within the scatter of the next). At a limit, above all of these: compound 3.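

In this assay, among these compounds, 4-fluorophenyl in place of 1H-indol-6-yl on an aromatic carbon, para to a large group, gives a 1.4-fold higher number from compound 2 to compound 4 (0.15 log units; within the scatter), the only step here that isolates a single change. The exchange removes the five-membered aromatic ring and the hydrogen-bond donor of the indolyl group, yet this pair shows no readable change, and compound 4 returns a number and not a limit. No measurement shown bears on why these two aryl groups read alike.

As far as these compounds go, one pair sets no pattern, so it remains open whether this insensitivity extends to other groups at this position, such as an aryl group carrying an amine or a carboxylic acid. The hydroxymethyl group is also common to compound 2 and compound 4, which leaves open how the number would respond if a longer chain, such as hydroxyethyl, or a carboxylic acid stood in its place on the aniline ring.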